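A few compounds are considered here, and "the series" means these few. Any claim that something is new, unique, unknown or untested is made for them only; others in the source may bear on it.

Measured compounds:
- compound 1 `O=C(OCC(F)(F)F)c1ccsc1NC(=O)[C@@H]1CCCN1`: 89.7 ug/mL
- compound 2 `O=C(OC1CCCCC1)c1ccsc1NC(=O)[C@@H]1CCCN1`: 162 ug/mL
- compound 3 `COC(=O)c1sccc1NC(=O)[C@@H]1CCCN1`: 163 ug/mL

All three share a core in which a thiophene-type ring carries an ester on one side and a prolinamide on the other, and all were tested in a functional assay on MCF7 cells (Homo sapiens) for inhibition; on this read-out higher numbers stand for weaker inhibition of growth and lower numbers for stronger inhibition of growth. Compound 2 sits second highest of the three numbers, but every gap among them is within the scatter, so the three are best read as equal. For the measured compounds named here, the one step that changes the group on the ester oxygen, a 1.8-fold higher number from compound 1 to compound 2 (0.26 log units; within the scatter), stayed within the scatter.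

Compound 4 `O=C(Oc1ccccc1)c1ccsc1NC(=O)[C@@H]1CCCN1` has not been measured. It differs from compound 2 as follows: phenyl in place of cyclohexyl on an oxygen next to a carbonyl group. Going by the values given here, no measured step swaps a saturated ring for an aromatic one on this oxygen, so the only guide is that the earlier change at the same place, from compound 1 to compound 2, moved the number very little. The expectation is therefore a step of no more than the scatter in either direction, a 1.1-fold lower number from compound 2 to compound 4 (0.03 log units; within the scatter). Compound 4 is estimated to give 150 ug/mL, with a likely range from 60 ug/mL to 400 ug/mL.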

Compound 4, concentration for 50% growth inhibition: > 250 ug/mL
Compound 4: only a limit was reported; the forecaster's own chance of this, stated with the estimate: 20%; middle value at least 1.6-fold (0.22 log units) away from the limit.
By their numbers in this assay, from the lowest: compounds 1, 2 and 3 (each within the scatter of the next). At a limit, above all of these: compound 4.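

In this assay, putting phenyl in place of cyclohexyl on this oxygen gives an at least 1.5-fold higher number from compound 2 to compound 4 (0.18 log units; that floor lies within the scatter) and so does not by itself separate the two compounds. For the compounds shown here, putting phenyl in place of 2,2,2-trifluoroethyl gives an at least 2.7-fold higher number from compound 1 to compound 4 (0.44 log units; beyond the scatter) and is the first step at this oxygen to clear the scatter, which shows that the group here can weaken growth inhibition measurably. Compound 4 is reported only as a limit and not as a number: the limit of > 250 ug/mL in this assay, at which 1 of the 4 values shown sits.

Going by these compounds, how far the number of compound 4 lies past that limit stays open, and with it the full size of both steps. Also open, on these data alone, is what a longer chain on this oxygen would do, or a phenyl ring carrying an amine or a carboxylic acid.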